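Morpholin-4-yl on the carbonyl carbon: notes toward compound 3

The source may report more compounds than this note shows. Statements on the series, on what has been measured and on what is new or still open speak of the compounds shown alone.

In an ADME assay on microsomes from liver (Homo sapiens) for metabolic stability, with a stated time of 10 min (a higher number here means that more of the compound is left, a lower number that less of the compound is left), compound 1 `CC(=O)N1CC[C@@H](C(=O)N2CC[C@](c3ccc(C(OCc4c(F)cccc4F)(C(F)(F)F)C(F)(F)F)cc3)(S(=O)(=O)c3ccc(F)cc3)C2)C1` gives 9% and compound 2 `CC(=O)N1CCC(O)(C(=O)N2CC[C@](c3ccc(C(OCc4c(F)cccc4F)(C(F)(F)F)C(F)(F)F)cc3)(S(=O)(=O)c3ccc(F)cc3)C2)CC1` gives 16%, so compound 2 does not stand apart from compound 1. Compound 3 `O=C(N1CCOCC1)N1CC[C@](c2ccc(C(OCc3c(F)cccc3F)(C(F)(F)F)C(F)(F)F)cc2)(S(=O)(=O)c2ccc(F)cc2)C1` carries morpholin-4-yl in place of 1-acetyl-4-hydroxypiperidin-4-yl on a carbonyl carbon. Among the measured compounds shown here, the only measured step at this place is a number 7 percentage points higher from compound 1 to compound 2 (within the scatter), and no measured compound carries morpholin-4-yl. No change beyond the scatter is therefore expected, and the expected step is a number 4 percentage points higher from compound 2 to compound 3 (within the scatter). The estimate for compound 3 is 20%, within an expected range of 7% to 42%.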

Compound 3, percent of the compound remaining: 3%
The estimate for compound 3 lay 17 percentage points above the measured number; measured number below the stated range.
By their numbers in this assay, from the lowest: compounds 3, 1 and 2 (each within the scatter of the next, the first and the last beyond it).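

In this assay, this place on the carbonyl carbon now shows a step beyond the scatter: a number 13 percentage points lower from compound 2 to compound 3 (beyond the scatter) with morpholin-4-yl in place of 1-acetyl-4-hydroxypiperidin-4-yl. Set against 1-acetylpyrrolidin-3-yl, the same group gives a number 6 percentage points lower from compound 1 to compound 3 (within the scatter) as its step, so the separation holds against only one of the two earlier groups. Nothing measured accounts for the step. Still open, from the compounds shown here alone, is how a primary amine or a carboxylic acid on the group at this carbonyl carbon would read in this assay. Going by these compounds, the effect of changes elsewhere on the shared core also remains open.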